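Ether chain variation at the aromatic oxygen

The compounds below may be only part of what the source reports. "The series", "measured", "known", "first", "only" and "open" are said of these compounds alone.

Compound 2 `CCCOc1nc(N)nc2c1ncn2/C=C1/CC1(CO)CO` is the propoxy member of the series; compound 1 `CCCNc1nc(N)nc2c1ncn2/C=C1/CC1(CO)CO` carries propylamino on the same aromatic carbon and compound 3 `CCCCCOc1nc(N)nc2c1ncn2/C=C1/CC1(CO)CO` pentyloxy. In an ADME assay on HFF cells (Homo sapiens) for cytotoxicity, with a stated time of 8 days (on this read-out lower numbers stand for higher toxicity in this test and higher numbers for lower toxicity in this test), compound 1 returns only a limit of the assay, > 300000 nM. Compound 2 likewise returns only a limit in this assay, > 300000 nM. Compound 3 gives a number in this assay, 259000 nM. Compound 2 therefore stands with compound 1 at a limit rather than a number, and two of the three values shown sit at the limit of > 300000 nM in this assay, at which 2 of the 3 values shown sit. The step that the two limits leave unreadable from compound 1 to compound 2 cannot be read, while the steps of an at least 1.1-fold lower number from compound 1 to compound 3 (0.06 log units; that floor lies within the scatter) and an at least 1.1-fold lower number from compound 2 to compound 3 (0.06 log units; that floor lies within the scatter) are floors that lie within the scatter.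

Compound 4 `COCCOc1nc(N)nc2c1ncn2/C=C1/CC1(CO)CO` differs from compound 2 by methoxy in place of methyl on a saturated chain carbon, two bonds along the chain from an oxygen on an aromatic ring. Among the measured compounds shown here, the one measured change on the same chain, from compound 2 to compound 3, stayed within the scatter, and the change of the atom on the aromatic carbon was unreadable. None of the three compounds shifts this assay beyond the scatter, so for compound 4 no step beyond the scatter is expected in either direction. Compound 4 is expected to give 300000 nM, within 150000 nM to 600000 nM. The estimated step is a number no higher from compound 2 to compound 4 (the limit leaves the size open), and a limit rather than a number is the likelier report.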

Compound 4, half-maximal cytotoxic concentration: > 300000 nM
Compound 4 was reported as a limit; the forecaster's own chance of this, stated with the estimate: 70%; the middle value sits exactly at the limit.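

In this assay compound 4 stands with compound 1 and compound 2 at a limit rather than a number, so methoxy in place of methyl on a saturated chain carbon, two bonds along the chain from an oxygen on an aromatic ring, still gives no readable value, and the steps to compound 4 from those two compounds cannot be read. Among the compounds shown here, the one readable step is an at least 1.1-fold higher number from compound 3 to compound 4 (0.06 log units; that floor lies within the scatter), so the 2-methoxyethoxy chain is not separated from the pentyloxy chain in this test. The new member adds to the group at the limit, and the series now gathers at one end of the read-out: the limit of > 300000 nM in this assay, at which 3 of the 4 values shown sit.

Going by these compounds, how far the true values lie past the limit stays open, so nothing ranks the propylamino, propoxy and 2-methoxyethoxy members against one another. On these data alone, it is also open whether an amine or a carboxylic acid in place of the 2-methoxyethoxy chain, or a chain longer than pentyloxy, would give a number that departs from the limit by more than the scatter.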